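A few compounds are considered here, and "the series" means these few. Any claim that something is new, unique, unknown or untested is made for them only; others in the source may bear on it.

Compound 1 `O=C1OC(Cc2nc(-c3ccc(-c4ccccc4)cc3)no2)c2ccccc21`: in an ADME assay on RAW264.7 cells (Mus musculus) for cytotoxicity, read by MTT assay, with a stated time of 24 h, in the presence of a further agent that is not named here (a higher number here means a weaker inhibitor, a lower number a stronger inhibitor), compound 1 gives > 40000 nM, a limit of the assay and not a number.
Compound 2 `COc1cc(OC)c2c(c1)C(C(O)c1ccc(OCCOc3ccccc3)cc1)OC2=O`: in this assay compound 2 gives > 40000 nM, again a limit of the assay and not a number.

Compound 2 thus stands at the top of what this assay reports, and the limit of > 40000 nM in this assay, at which 2 of the 2 values shown sit, shows that every measured value in the set sits there. Within the data shown here, no pair of measured compounds differs in one place, so the data contain no step that tells how a change to the side chain moves the read-out. Compound 3 `COc1cc(OC)c2c(c1)C(C(O)c1ccc(OCc3ccc(OC(F)F)cc3)cc1)OC2=O` differs from compound 2 in one place: 4-(difluoromethoxy)phenyl in place of phenoxymethyl on a saturated chain carbon bound to an oxygen on an aromatic ring. With both measured values resting at the limit, the step from compound 2 to compound 3 in this assay is expected to be none beyond the scatter, estimated as a step that the limit leaves unreadable from compound 2 to compound 3. Compound 3 is therefore expected to give 60000 nM, within a range from 25000 nM to 200000 nM, most probably reported once more as a limit rather than a number.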

Compound 3, half-maximal inhibitory concentration: > 40000 nM
Compound 3: no number, only a limit; the forecaster's own chance of this, stated with the estimate: 80%; the middle value is on the limit's open side.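

In this assay compound 3, like compound 2, gives only a limit and not a number, so no step between compound 2 and compound 3 can be read: the limit of > 40000 nM in this assay, at which 3 of the 3 values shown sit.

The compounds shown leave open whether any change to the side chain moves the read-out in this assay at all.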